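Piperidine replaces hydroxypyrrolidine on the benzylic carbon

A few compounds are considered here, and "the series" means these few. Any claim that something is new, unique, unknown or untested is made for them only; others in the source may bear on it.

Compound 3 `CN1CCN(CCCN(c2nc3cc(F)c(F)cc3[nH]2)[C@@H]2CC[C@]3(c4cccc(CN5CC[C@H](O)C5)c4)C[C@@H]3C2)CC1` gives 441 nM in an assay on isolated protein for binding affinity to melanin-concentrating hormone receptor 1 (Homo sapiens) (on this read-out lower numbers stand for stronger inhibition and higher numbers for weaker inhibition), the highest number among the three measured compounds; compound 1 `CN1CCN(CCCN(c2nc3cc(F)c(F)cc3[nH]2)[C@@H]2CC[C@]3(c4cccc(CO)c4)C[C@@H]3C2)CC1` gives 70.8 nM and compound 2 `CN1CCN(CCCN(c2nc3cc(F)c(F)cc3[nH]2)[C@@H]2CC[C@]3(c4cccc(CN5CCCC5)c4)C[C@@H]3C2)CC1` gives 25.7 nM. Compound 4 `CN1CCN(CCCN(c2nc3cc(F)c(F)cc3[nH]2)[C@@H]2CC[C@]3(c4cccc(CN5CCCCC5)c4)C[C@@H]3C2)CC1` differs from compound 3 by piperidin-1-yl in place of 3-hydroxypyrrolidin-1-yl on a saturated chain carbon bound to an aromatic carbon. Going by the values given here, two measured steps bear on this change: the hydroxy on the saturated ring carbon cost a 17-fold higher number from compound 2 to compound 3 (1.23 log units; beyond the scatter), while swapping hydroxy for pyrrolidin-1-yl gave a 2.8-fold lower number from compound 1 to compound 2 (0.44 log units; beyond the scatter). Since compound 4 removes that ring hydroxy and keeps a cyclic amine, a large step down in this assay is expected, estimated at a 13-fold lower number from compound 3 to compound 4 (1.10 log units; beyond the scatter). Compound 4 is therefore expected to give 35 nM, within a range of 12 nM to 110 nM.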

Compound 4, inhibition constant: 405 nM
Estimate against measurement, compound 4: 12-fold (1.06 log units) below, and the stated range ends below it.
By their numbers in this assay, from the lowest: compound 2; then compound 1; then compounds 4 and 3 (each within the scatter of the next).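

In this assay, piperidin-1-yl and 3-hydroxypyrrolidin-1-yl on this saturated chain carbon cannot be told apart (a 1.1-fold lower number from compound 3 to compound 4 (0.04 log units; within the scatter)). Thus a hydroxy-free cyclic amine does not by itself match compound 2: the six-membered ring in place of the five-membered pyrrolidin-1-yl ring gives a large loss (a 16-fold higher number from compound 2 to compound 4 (1.20 log units; beyond the scatter)), and piperidin-1-yl also falls short of the hydroxy of compound 1 (a 5.7-fold higher number from compound 1 to compound 4 (0.76 log units; beyond the scatter)). The data shown offer no explanation for these steps.

On these data alone, it remains open whether ring size alone governs this position. Azetidine, morpholine or an open-chain dimethylamino group on the same carbon could test this.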